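The source may hold more compounds than are shown below. What is called first, only, known or untested is meant among the compounds shown, and "the series" means these compounds.

Measured compounds:
compound 1, `CN(C)c1ncnc2c1ncn2Cc1ccc(F)cc1` — 33%
compound 2, `CN(C)c1ncnc2c1ncn2Cc1ccc([N+](=O)[O-])cc1` — 0%

In a functional assay on the whole organism for inhibition, with Rattus norvegicus as the target, in the maximal electroshock model, at a dose of 25 mg/kg by the intraperitoneal route (on this read-out lower numbers stand for less inhibition and higher numbers for more inhibition at the one dose given (going by the name of the read-out)), compound 1 gives 33%, while compound 2 gives 0%. Among the measured compounds shown here, compound 2 stands lowest of the two numbers, at the bottom of the scale, and the one measured step, a number 33 percentage points lower from compound 1 to compound 2 (beyond the scatter), is a large drop.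

Compound 3, `CN(C)c1ncnc2c1ncn2Cc1ccc(C#N)cc1`, differs from compound 2 in one place: cyano in place of nitro on an aromatic carbon. For the measured compounds named here, no measured step exchanges nitro for cyano, so the data give no size for this change. Going by the values given here, the one step known, a number 33 percentage points lower from compound 1 to compound 2 (beyond the scatter), shows only that the nitro compound gave the low number; it says nothing about cyano. Since compound 2 already sits at the bottom, a further drop in this assay is not possible; a rise is possible but unsupported. Compound 3 is therefore expected to give about 10%, in a range from 0% to 30%. This estimate means an expected step of a number 10 percentage points higher from compound 2 to compound 3 (within the scatter), within the scatter.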

Compound 3, a percentage reported as inhibition, in the whole organism at one dose (the size of the read-out at that dose, not a potency): 0%
Compound 3: the middle estimate sits 10 percentage points above what was measured, and the stated range covers the measured number.
By their numbers in this assay, from the lowest: compounds 2 and 3 (each within the scatter of the next); then compound 1.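

In this assay, cyano in place of nitro on this aromatic carbon, para to a large group, gives no change at the digits printed from compound 2 to compound 3 (within the scatter), so the reading at the bottom of the scale is not confined to the nitro compound. Cyano in place of fluoro gives a number 33 percentage points lower from compound 1 to compound 3 (beyond the scatter), which leaves compound 1, with fluoro, as the only one of the three with a reading above that bottom. Nothing measured here tells why fluoro stands apart from nitro and cyano in this way.

Since compound 2 and compound 3 both lie at the bottom of the scale, this single dose cannot show whether they would differ at all at another one. Going by these compounds, it also remains open whether chloro, methoxy or an amine at this position would read like compound 1 or like compound 3.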